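The source may hold more compounds than are shown below. What is called first, only, known or untested is meant among the compounds shown, and "the series" means these compounds.

Compound 3 `O=C(Nc1ccc(Cl)cc1)N[C@H]1CC[C@H](Oc2ccc(F)cc2)CC1` gives in a functional assay on CRL2813 cells (Homo sapiens) for cytotoxicity, read by sulforhodamine B assay, with a stated time of 5 days (a lower number here means a stronger inhibitor, a higher number a weaker inhibitor), only the limit > 20000 nM. Compound 1 `O=C(Nc1cccc(F)c1)N[C@H]1CC[C@H](Oc2ccc(F)cc2)CC1` gives in this assay 8300 nM. Compound 2 `CSc1ccccc1NC(=O)N[C@H]1CC[C@H](Oc2ccc(F)cc2)CC1` gives in this assay only the limit > 20000 nM. The move from compound 1 to compound 2 reads an at least 2.4-fold higher number from compound 1 to compound 2 (0.38 log units; beyond the scatter), and from compound 1 to compound 3 an at least 2.4-fold higher number from compound 1 to compound 3 (0.38 log units; beyond the scatter); between compound 2 and compound 3 the two limits leave a step that the two limits leave unreadable from compound 2 to compound 3. Two of the three values sit at the limit of > 20000 nM in this assay, at which 2 of the 3 values shown sit. Compound 4 `O=C(Nc1ccccc1Br)N[C@H]1CC[C@H](Oc2ccc(F)cc2)CC1` carries the change (2-bromophenyl in place of 4-chlorophenyl on an amide-type nitrogen). Compound 2 with its 2-(methylsulfanyl)phenyl already sits at the limit, so for compound 4 no gain beyond the scatter is expected, and the step of a number no higher from compound 3 to compound 4 (the limit leaves the size open) is the estimate. Compound 4 is expected at 20000 nM, within 6000 nM to 60000 nM.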

Compound 4, half-maximal inhibitory concentration: 7700 nM
The estimate for compound 4 lay 2.6-fold (0.41 log units) above the measured number, within the range that was stated.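

On the amide-type nitrogen, 2-bromophenyl gives a readable number in this assay, with an at least 2.5-fold lower number from compound 3 to compound 4 (0.41 log units; beyond the scatter) and an at least 2.5-fold lower number from compound 2 to compound 4 (0.41 log units; beyond the scatter). The second step shows that the group carried on this phenyl matters here, since 2-bromophenyl and 2-(methylsulfanyl)phenyl do not read alike. Against 3-fluorophenyl the result is a 1.1-fold lower number from compound 1 to compound 4 (0.03 log units; within the scatter), so these two groups cannot be told apart in this assay.

Going by these compounds, the full size of the steps out of the limit, and the step between compound 2 and compound 3, cannot be read: the limit of > 20000 nM in this assay, at which 2 of the 4 values shown sit. Whether 2-chlorophenyl or 2-aminophenyl would read like 2-bromophenyl stays open.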